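Series notes: acyl extension on the ring nitrogen

This account rests on a few compounds, and the source may have more. Where it says the series, first, only, none or still open, it means among the compounds named here.

Compound 2 `CCOC(=O)/C=C/C(=O)N(CC(N)=O)NC(=O)[C@@H]1CCCN1C(C)=O` gives 8.3 nM in an assay on isolated protein for inhibition of legumain (Mus musculus), read by fluorescence, with stated times of 30 s and 2.5 h (a lower number here means a stronger inhibitor, a higher number a weaker inhibitor), the lowest of the two numbers in hand; compound 1 `CCOC(=O)/C=C/C(=O)N(CC(N)=O)NC(=O)[C@@H]1CCCN1C(=O)[C@H]1CSCN1C(C)=O` gives 167 nM in this assay. Compound 3 `CCOC(=O)/C=C/C(=O)N(CC(N)=O)NC(=O)[C@@H]1CCCN1C(=O)[C@H]1CCCCN1C(C)=O` differs from compound 2 by a group of 9 heavy atoms (7 carbon, 1 nitrogen, 1 oxygen; one six-membered non-aromatic ring with 1 hetero atom) in place of one carbon atom, on a carbonyl carbon. Among the compounds with values here, the one measured step that bears on this is the reverse of such an extension: the step of a 20-fold lower number from compound 1 to compound 2 (1.30 log units; beyond the scatter) went with removal of a comparable ring-bearing acyl group from the same carbonyl carbon. A step of similar size in the opposite direction is therefore expected, giving a 12-fold higher number from compound 2 to compound 3 (1.08 log units; beyond the scatter). Compound 3 is estimated at 100 nM, with a range from 30 nM to 400 nM.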

Compound 3, half-maximal inhibitory concentration: 638 nM
Estimate against measurement, compound 3: 6.4-fold (0.80 log units) below, outside the stated range (above it).
By their numbers in this assay, from the lowest: compound 2; then compound 1; then compound 3.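

With a 77-fold higher number from compound 2 to compound 3 (1.89 log units; beyond the scatter) in this assay on replacing methyl, the loss seen with the ring-bearing acyl group of compound 1 recurs with a second such group, so it is not particular to one ring. The two ring-bearing groups are also not interchangeable, with a 3.8-fold higher number from compound 1 to compound 3 (0.58 log units; beyond the scatter) on going to the six-membered ring. Nothing at hand accounts for either step.

On these data alone, whether a propionyl group or an acyl chain carrying an amine in place of the methyl stays close to compound 2 remains open. So does the effect of removing the acetyl group from the six-membered ring of compound 3.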